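This account rests on a few compounds, and the source may have more. Where it says the series, first, only, none or still open, it means among the compounds named here.

Measured compounds:
compound 1, `CC(C)=CCc1cc(C(=O)Nc2cc3ccc(OCC4CCCNC4)c(C)c3oc2=O)ccc1O` — in a functional assay on MCF7 cells (Homo sapiens) for antiproliferative activity (on this read-out higher numbers stand for weaker inhibition and lower numbers for stronger inhibition), compound 1 gives 790 nM
compound 2, `CC(C)=CCc1cc(C(=O)Nc2cc3ccc(OCC4CCN(C)C4)c(C)c3oc2=O)ccc1O` — in this assay compound 2 gives 1550 nM
compound 3, `CC(C)=CCc1cc(C(=O)Nc2cc3ccc(OCCCNC(C)C)c(C)c3oc2=O)ccc1O` — in this assay compound 3 gives 740 nM

Compound 2 carries the highest of the three numbers, although its step to compound 1 is small: a 2.0-fold higher number from compound 1 to compound 2 (0.29 log units; within the scatter). Against compound 3 it is separated more clearly, as a 2.1-fold lower number from compound 2 to compound 3 (0.32 log units; beyond the scatter) shows, while compound 1 and compound 3 sit close together, a 1.1-fold lower number from compound 1 to compound 3 (0.03 log units; within the scatter).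

Compound 4, `CC(C)=CCc1cc(C(=O)Nc2cc3ccc(OCCCNCCO)c(C)c3oc2=O)ccc1O`, is not yet measured. It differs from compound 2 in one place: 2-((2-hydroxyethyl)amino)ethyl in place of 1-methylpyrrolidin-3-yl on a saturated chain carbon bound to an oxygen on an aromatic ring. Among the compounds with values here, the step that bears most directly on this change is the one from compound 2 to compound 3, where the ring was likewise replaced by an open chain carrying a secondary amine, and the number fell by a modest amount beyond the scatter. The present change also opens the ring and restores the amine hydrogen, so compound 4 is expected to move in the same direction, a 1.8-fold lower number from compound 2 to compound 4 (0.26 log units; within the scatter), landing near compound 3 and compound 1 rather than near compound 2. For compound 4 the estimate in this assay is 850 nM, with a range from 400 nM to 1800 nM.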

Compound 4, half-maximal inhibitory concentration: 1560 nM
Beside the measured number, compound 4's estimate is 1.8-fold (0.26 log units) below it, and the stated range covers the measured number.
By their numbers in this assay, from the lowest: compounds 3, 1, 2 and 4 (each within the scatter of the next, the first and the last beyond it).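

In this assay, an open chain carrying a secondary amine does not by itself set a compound apart from the ring-bearing compounds, as a 1.0-fold higher number from compound 2 to compound 4 (0.00 log units; within the scatter) and a 2.0-fold higher number from compound 1 to compound 4 (0.30 log units; within the scatter) both stay within the scatter. The new information lies on the amine nitrogen, where 2-hydroxyethyl in place of isopropyl gives a 2.1-fold higher number from compound 3 to compound 4 (0.32 log units; beyond the scatter), a modest step beyond the scatter with the rest of the chain unchanged, so the number here depends on that substituent and not only on whether the ring is open. No measurement at hand accounts for this step.

From the compounds shown here alone, whether a 2-methoxyethyl or a plain ethyl on that amine nitrogen would fall nearer compound 3 or compound 4 remains open. So does the outcome of a longer chain between the aromatic oxygen and the amine.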